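The source may report more compounds than this note shows. Statements on the series, on what has been measured and on what is new or still open speak of the compounds shown alone.

Measured in a functional assay on A549 cells (Homo sapiens) for inhibition, read by sulforhodamine B assay, with a stated time of 48 h; on this read-out higher numbers stand for weaker inhibition of growth and lower numbers for stronger inhibition of growth:
- compound 1 `COc1cc(/C=C/C(=O)/C(=C/c2cc(OC)c(OC)c(OC)c2)C(C)=O)cc(OC)c1OC`: 530 nM
- compound 2 `COc1ccc(/C=C/C(=O)C(=Cc2cc(OC)c(OC)c(OC)c2)C(=O)/C=C/c2ccc(OC)c(OC)c2)cc1OC`: 230 nM

Compound 2 has the lower of the two numbers at 230 nM, and compound 1 stands higher at 530 nM, a gap beyond the usual scatter. The next compound to be tested is compound 3 `COc1cc(C=C(C(=O)/C=C/c2ccc(OC)c(OC)c2)C(=O)/C=C/c2ccc(OC)c(OC)c2)ccc1O`. Its change from compound 2 is 4-hydroxy-3-methoxyphenyl in place of 3,4,5-trimethoxyphenyl on a double-bonded chain carbon bound to a double-bonded chain carbon.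

Within the data shown here, no measured pair isolates this change, so the expectation is anchored only on compound 2 at 230 nM. In this assay a small move toward a higher number is expected, possibly no larger than the scatter. The estimated step is a 1.3-fold higher number from compound 2 to compound 3 (0.12 log units; within the scatter). For compound 3 the expected value is 300 nM, with an estimated range of 100 nM to 900 nM.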

Compound 3, concentration for 50% growth inhibition: 530 nM
Compound 3: middle estimate off by 1.8-fold (0.25 log units), on the low side; the range from low to high includes it.
By their numbers in this assay, from the lowest: compound 2; then compounds 1 and 3 (each within the scatter of the next).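

In this assay, the place on a double-bonded chain carbon bound to a double-bonded chain carbon responds to a change of aryl group: 4-hydroxy-3-methoxyphenyl in place of 3,4,5-trimethoxyphenyl gives a 2.3-fold higher number from compound 2 to compound 3 (0.36 log units; beyond the scatter). This single-place pair shows that, in this one case, the incoming group, with its hydrogen-bond donor, does not keep the lower number of compound 2. No supporting measurement bears on why the number rises.

The step exchanges the two groups whole, so the compounds shown do not separate the gain of the hydroxy group from the loss of methoxy groups. Also open, going by these compounds, is how this place would respond to a phenyl ring carrying an amine or a carboxylic acid.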